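Piperidine amide in place of an oxolanyl amine

A few compounds are considered here, and "the series" means these few. Any claim that something is new, unique, unknown or untested is made for them only; others in the source may bear on it.

Compound 3 `CCN(CC)S(=O)(=O)c1ccc(S(=O)(=O)N2CCC[C@@H](C(=O)N[C@@H]3CCOC3)C2)cc1` is tested in a functional assay on MIA PaCa-2 cells (Homo sapiens) for inhibition, read by MTT assay, with a stated time of 7 days (on this read-out higher numbers stand for weaker inhibition and lower numbers for stronger inhibition), where compound 3 gives 750 nM. Among the three measured compounds this number is the second highest. Compound 1 `CCN(CC)S(=O)(=O)c1ccc(S(=O)(=O)N2CCC[C@@H](C(=O)N3CCS(=O)(=O)CC3)C2)cc1` gives 900 nM, and the comparison reads a 1.2-fold lower number from compound 1 to compound 3 (0.08 log units; within the scatter). Compound 2 `CCN(CC)S(=O)(=O)c1ccc(S(=O)(=O)N2CCC[C@@H](C(=O)N3CCC(C(F)(F)F)CC3)C2)cc1` gives 320 nM, and here the comparison reads a 2.3-fold higher number from compound 2 to compound 3 (0.37 log units; beyond the scatter).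

Compound 4 `CCN(CC)S(=O)(=O)c1ccc(S(=O)(=O)N2CCC[C@@H](C(=O)N3CCC(COC)CC3)C2)cc1` differs from compound 3 in one place: 4-(methoxymethyl)piperidin-1-yl in place of (oxolan-3-yl)amino on a carbonyl carbon. Going by the values given here, two measured steps bear on this change. The step of a 2.3-fold higher number from compound 2 to compound 3 (0.37 log units; beyond the scatter) shows that moving from a piperidine amide to the (oxolan-3-yl)amino group raised the number, and the step of a 2.8-fold lower number from compound 1 to compound 2 (0.45 log units; beyond the scatter) shows a piperidine amide doing better than the 1,1-dioxothiomorpholin-4-yl amide. Compound 4 returns to a piperidine amide, yet with 4-(methoxymethyl)piperidin-1-yl rather than the 4-(trifluoromethyl)piperidin-1-yl of compound 2, so only part of the gain seen for compound 2 is expected to carry over. The expected step is therefore a 1.7-fold lower number from compound 3 to compound 4 (0.22 log units; within the scatter), a modest lowering. Compound 4 is estimated to give 450 nM, within a range from 200 nM to 1000 nM.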

Compound 4, half-maximal inhibitory concentration: 250 nM
For compound 4 the middle estimate is 1.8-fold (0.26 log units) above the measured one, within the range that was stated.
By their numbers in this assay, from the lowest: compounds 4 and 2 (each within the scatter of the next); then compounds 3 and 1 (each within the scatter of the next).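

In this assay, 4-(methoxymethyl)piperidin-1-yl on the carbonyl carbon gives a 3.0-fold lower number from compound 3 to compound 4 (0.48 log units; beyond the scatter) and a 3.6-fold lower number from compound 1 to compound 4 (0.56 log units; beyond the scatter), so a second piperidine amide now stands clear of both the (oxolan-3-yl)amino and the 1,1-dioxothiomorpholin-4-yl amides. Methoxymethyl in place of trifluoromethyl on the saturated ring carbon gives a 1.3-fold lower number from compound 2 to compound 4 (0.11 log units; within the scatter), so the two piperidine amides cannot be told apart here and the lower numbers of this pair do not depend on trifluoromethyl alone. Nothing measured here accounts for this result.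

From the compounds shown here alone, it remains open whether a piperidine amide with no group on the ring, or one carrying hydroxymethyl or a carboxylic acid, would give numbers like these. Going by these compounds, it is also open whether a longer ether chain in place of methoxymethyl would do the same.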